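A few compounds are considered here, and "the series" means these few. Any claim that something is new, unique, unknown or untested is made for them only; others in the source may bear on it.

Measured so far in a functional assay on HepG2 cells (Homo sapiens) for inhibition, read by MTT assay, with a stated time of 48 h; a higher number here means a weaker inhibitor, a lower number a stronger inhibitor:
compound 1 `COc1ccc(N(C)c2nc(C)nc3ccccc23)cc1OCCCCCC[Se]C#N` gives 4890 nM
compound 2 `COc1ccc(N(C)c2nc(C)nc3ccccc23)cc1C(=O)NCC[Se]C#N` gives 179 nM

Compound 2 stands lowest of the two measured compounds, which makes it the stronger inhibitor. Among the measured compounds shown here, the only measured step is a 27-fold lower number from compound 1 to compound 2 (1.44 log units; beyond the scatter) and it lies well beyond the scatter. Compound 3 `COc1ccc(N(C)c2nc(C)nc3ccccc23)cc1C(=O)OCCCC[Se]C#N` keeps the shared core and changes the group on a carbonyl carbon: a group of 8 heavy atoms (5 carbon, 1 nitrogen, 1 oxygen, 1 selenium; no ring) in place of a group of 6 heavy atoms (3 carbon, 2 nitrogen, 1 selenium; no ring), on a carbonyl carbon is the difference. For the measured compounds named here, the measured step also swapped a whole group, and it shows only that such swaps can move the number far in this assay when the group changes. Going by the values given here, no measured step isolates the present change. A moderate rise is expected, placing compound 3 between compound 2 and compound 1 at 4890 nM on the scale. The expected move is a 3.4-fold higher number from compound 2 to compound 3 (0.53 log units; beyond the scatter) as estimated from this single step. For compound 3 the estimated value is 600 nM with 150 nM to 2500 nM as the expected span.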

Compound 3, half-maximal inhibitory concentration: 975 nM
Compound 3: middle estimate off by 1.6-fold (0.21 log units), on the low side, within the range that was stated.
By their numbers in this assay, from the lowest: compound 2; then compound 3; then compound 1.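

In this assay the swap on the carbonyl carbon matters: replacing the group that carries the amide hydrogen with a group of 8 heavy atoms and 0 hydrogen-bond donors gives a 5.4-fold higher number from compound 2 to compound 3 (0.74 log units; beyond the scatter) and so a weaker inhibitor. Even so, the compound with the ester link keeps much of the gain over the chain joined through oxygen on the aromatic carbon, with a 5.0-fold lower number from compound 1 to compound 3 (0.70 log units; beyond the scatter) as the step between them. Nothing available explains why the number moves in either step.

The link and the chain length changed together here, so their shares of the step cannot be separated. An amide carrying a longer chain, or an ester carrying the shorter chain of compound 2, would be needed to tell them apart.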